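The source may report more compounds than this note shows. Statements on the series, on what has been measured and on what is new or still open speak of the compounds shown alone.

Three members of the series share one core and differ only in the group on the sulfonyl sulfur. Compound 1 `CC(C)S(=O)(=O)NC(=O)c1ccc(Nc2nc(NC3(c4ccc(Cl)cc4)CC3)nc(OCC(F)(F)F)n2)cc1` carries isopropyl there; in an ADME assay on microsomes from liver (Homo sapiens) for metabolic stability, with a stated time of 10 min (a higher number here means that more of the compound is left, a lower number that less of the compound is left), compound 1 gives 100%. Compound 2 `CC(C)NCCS(=O)(=O)NC(=O)c1ccc(Nc2nc(NC3(c4ccc(Cl)cc4)CC3)nc(OCC(F)(F)F)n2)cc1` carries 2-(isopropylamino)ethyl, and in this assay compound 2 gives 89%. Compound 3 `CC(C)(C)CNCCS(=O)(=O)NC(=O)c1ccc(Nc2nc(NC3(c4ccc(Cl)cc4)CC3)nc(OCC(F)(F)F)n2)cc1` carries 2-(neopentylamino)ethyl; in this assay compound 3 gives 89%, which is no change at the digits printed from compound 2 to compound 3 (within the scatter) and a number 11 percentage points lower from compound 1 to compound 3 (beyond the scatter). Compound 3 thus sits level with compound 2, the two together at the lowest of the three numbers.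

Compound 4 `CS(=O)(=O)NC(=O)c1ccc(Nc2nc(NC3(c4ccc(Cl)cc4)CC3)nc(OCC(F)(F)F)n2)cc1` is reached from compound 3 by hydrogen in place of (neopentylamino)methyl on a saturated chain carbon bound to a sulfonyl sulfur. The measured steps bearing on this are a number 11 percentage points lower from compound 1 to compound 3 (beyond the scatter) and a number 11 percentage points lower from compound 1 to compound 2 (beyond the scatter), both modest, both in the same direction, while no change at the digits printed from compound 2 to compound 3 (within the scatter) shows that the group on the amine nitrogen leaves the number where it was. Taking the whole chain away is therefore expected to reverse the modest drop, a step of a number 8 percentage points higher from compound 3 to compound 4 (within the scatter). Compound 4 is expected to give about 97% in this assay, within 86% to 100%.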

Compound 4, percent of the compound remaining: 100%
Estimate against measurement, compound 4: 3 percentage points below; the measured number falls inside the stated range.
By their numbers in this assay, from the lowest: compounds 2 and 3 (each within the scatter of the next); then compounds 1 and 4 (each within the scatter of the next).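

Cutting the chain back to methyl on the sulfonyl sulfur gives a number 11 percentage points higher from compound 3 to compound 4 (beyond the scatter) in this assay, and the same change from the isopropylamino chain gives a number 11 percentage points higher from compound 2 to compound 4 (beyond the scatter), so the modest loss with these two amine chains now shows against a second short group as well as against isopropyl. Methyl in place of isopropyl gives no change at the digits printed from compound 1 to compound 4 (within the scatter), so these two small groups on the sulfonyl sulfur cannot be told apart in this assay. Nothing available here gives a reason for the lower number with the amine chains.

Both chains carry an amine nitrogen and added length together, which leaves open which of the two goes with the loss. A plain butyl chain or a 2-methoxyethyl chain on the sulfonyl sulfur would separate them, and a carboxylic acid at the chain end would test a different terminal group.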